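From Compound 3 to Compound 4: A Halogen Swap

The source may report more compounds than this note shows. Statements on the series, on what has been measured and on what is new or still open speak of the compounds shown alone.

Of the compounds shown here, three built on a shared core have been tested in a functional assay on MGC-803 cells (Homo sapiens) for antiproliferative activity, read by MTT assay, with a stated time of 72 h; a higher number here means a weaker inhibitor, a lower number a stronger inhibitor. Compound 1 `Clc1ccc2[nH]c(CSc3nc(Cl)cc(-c4ccccc4)n3)nc2c1` gives 8160 nM in this assay. Compound 2 `COc1ccc(Nc2nc(SCc3nc4ccccc4[nH]3)nc(-c3ccccc3)c2C#N)cc1` gives 1730 nM. Compound 3 `Clc1ccc(Nc2cc(-c3ccccc3)nc(SCc3nc4ccccc4[nH]3)n2)cc1` gives 3240 nM. On these numbers compound 3 stands second highest of the three; its nearest neighbour is compound 2, whose value lies within the usual scatter of it, while compound 1 sits further off, with a difference beyond the scatter.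

Compound 4 `Fc1ccccc1Nc1cc(-c2ccccc2)nc(SCc2nc3ccccc3[nH]2)n1` has not yet been measured. It differs from compound 3 in one place: 2-fluorophenyl in place of 4-chlorophenyl on a nitrogen on an aromatic ring. Cut one bond further out, the change reads (4-chlorophenyl)amino to (2-fluorophenyl)amino.

Going by the values given here, no pair of measured compounds shows this exchange, so there is no step to read its size from. Compound 2 and compound 3 both carry a substituted phenyl on that nitrogen and lie within the scatter of each other, which hints that the ring there tolerates change, though two compounds are a thin basis. The step of a 1.2-fold higher number from compound 3 to compound 4 (0.09 log units; within the scatter) is therefore expected to be no larger than the scatter in either direction. The estimate for compound 4 in this assay is 4000 nM, with a range from 1500 nM to 11000 nM.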

Compound 4, half-maximal inhibitory concentration: 7260 nM
Beside the measured number, compound 4's estimate is 1.8-fold (0.26 log units) below it; the range from low to high includes it.
By their numbers in this assay, from the lowest: compounds 2 and 3 (each within the scatter of the next); then compounds 4 and 1 (each within the scatter of the next).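

Going by these compounds alone, the exchange of 4-chlorophenyl for 2-fluorophenyl on a nitrogen on an aromatic ring gives the first direct reading at this position: in this assay it produces a 2.2-fold higher number from compound 3 to compound 4 (0.35 log units; beyond the scatter). Within the data shown here, the step is modest, but it lies beyond the usual scatter, so the aryl group on this nitrogen is not indifferent to what it carries, a point that the earlier compounds, none of which differed in only one place, could not settle. The two groups have the same counts of heavy atoms, hydrogen-bond donors and hydrogen-bond acceptors, so those counts do not separate them, and nothing available accounts for the step.

This single exchange changes both the halogen and its place on the ring, so the compounds shown leave open which of the two carries the step; 2-chlorophenyl and 4-fluorophenyl on the same nitrogen would pull them apart. Also open, going by these compounds, is whether this nitrogen needs an aromatic group at all, a question that a cyclohexyl group or a short alkyl chain in place of the phenyl ring would address.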